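The source may hold more compounds than are shown below. What is called first, only, known or untested is meant among the compounds shown, and "the series" means these compounds.

Compound 2 `CCCCCc1c(C(C)C)nc(C(C)C)c(CO)c1-c1ccc(C)cc1` gives 1000 nM in an assay on CHO cells for inhibition of Glucagon receptor (Homo sapiens) (a higher number here means a weaker inhibitor, a lower number a stronger inhibitor), the lowest of the two numbers recorded, and its nearest neighbour, compound 1 `CCCCCc1c(C(C)C)nc(C(C)C)c(CO)c1-c1ccc(F)c(F)c1`, gives 1100 nM. Among the compounds with values here, the only measured step, a 1.1-fold lower number from compound 1 to compound 2 (0.04 log units; within the scatter), likewise exchanges the aryl group on the shared core and stays within the scatter. Compound 3 `CCCCCc1c(C(C)C)nc(C(C)C)c(CO)c1-c1cccc(OC)c1` differs from compound 2 by 3-methoxyphenyl in place of 4-methylphenyl on an aromatic carbon. Because a 1.1-fold lower number from compound 1 to compound 2 (0.04 log units; within the scatter) left this assay essentially unmoved, no step beyond the scatter is expected here either, and the expected step is no change at the digits printed from compound 2 to compound 3 (within the scatter). Compound 3 is therefore estimated at 1000 nM, with a range from 500 nM to 2200 nM.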

Compound 3, half-maximal inhibitory concentration: 48000 nM
Compound 3: middle estimate off by 48-fold (1.68 log units), on the low side; measured number above the stated range.
By their numbers in this assay, from the lowest: compounds 2 and 1 (each within the scatter of the next); then compound 3.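

In this assay, the aryl position opposite the ring nitrogen proves sensitive to the group it carries: a 48-fold higher number from compound 2 to compound 3 (1.68 log units; beyond the scatter), and a 44-fold higher number from compound 1 to compound 3 (1.64 log units; beyond the scatter), so 3-methoxyphenyl gives a much weaker inhibitor than either 4-methylphenyl or 3,4-difluorophenyl. The earlier pair, within the scatter of each other, gave no sign of such a drop. No evidence is available that explains it. The compounds shown leave open whether the step follows from the methoxy group itself or from its place on the phenyl ring. They also leave open how an amine or a carboxylic acid on that ring would read.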